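Effect of the 4-methylphenyl to phenyl change

This account rests on a few compounds, and the source may have more. Where it says the series, first, only, none or still open, it means among the compounds named here.

Among the measured compounds shown here, compound 1 `CCOC(=O)C1=Cc2ccccc2OC1(OCc1cn(-c2ccc(C)cc2)nn1)C(F)(F)F` is the one compound of this set with a number in a functional assay on MCF7 cells (Homo sapiens) for inhibition, read by MTT assay, with a stated time of 24 h; on this read-out higher numbers stand for weaker inhibition and lower numbers for stronger inhibition; there compound 1 gives 26700 nM. Compound 2 `CCOC(=O)C1=Cc2ccccc2OC1(OCc1cc(-c2ccc(Br)cc2)no1)C(F)(F)F` sits at a limit of the assay rather than at a number: in this assay compound 2 returns > 150000 nM. For compound 2 that limit, (the limit of > 150000 nM in this assay, at which 1 of the 2 values shown sits), is the only other reading shown. Compound 1 is therefore the sole anchor for the next step. Compound 3 `CCOC(=O)C1=Cc2ccccc2OC1(OCc1cn(-c2ccccc2)nn1)C(F)(F)F` differs from compound 1 in one place: hydrogen in place of methyl on an aromatic carbon; cut one bond further out, 4-methylphenyl becomes phenyl. For the measured compounds named here, no measured pair shows this change, so the size of the step has no precedent in the set. A step no larger than the usual scatter is expected in this assay, with no clear direction. The value of compound 3 in this assay is estimated at 35000 nM, between 12000 nM and 100000 nM. The expected step of a 1.3-fold higher number from compound 1 to compound 3 (0.12 log units; within the scatter) is accordingly small.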

Compound 3, half-maximal inhibitory concentration: > 150000 nM
Compound 3: a limit, no number (the forecaster's own chance of this, stated with the estimate: 15%); at least 4.2-fold (0.63 log units) between middle value and limit.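

In this assay, the methyl on the aromatic carbon para to a large group proves to matter: hydrogen in its place gives an at least 5.6-fold higher number from compound 1 to compound 3 (0.74 log units; beyond the scatter). Compound 3 sits at a limit of the assay, > 150000 nM, and not at a number. Within this pair, the measurable activity of compound 1 therefore depends on that methyl, but the full size of the step stays unread because one end of it is a limit: the limit of > 150000 nM in this assay, at which 2 of the 3 values shown sit.

On these data alone, whether an ethyl, a methoxy or a chlorine on the same aromatic carbon would keep, raise or lose the activity of compound 1 remains open. Compound 2 differs from compound 1 in more than one place, so it offers no comparison for this position.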